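The source may report more compounds than this note shows. Statements on the series, on what has been measured and on what is new or still open speak of the compounds shown alone.

Measured compounds:
Compound 1 `CC1(C)[C@H]2CC[C@]1(C)N(Cc1cn(-c3ccc(F)cc3)nn1)C(=O)C2` gives 90 nM in a functional assay on HepG2 cells (Homo sapiens) for inhibition, read by MTT assay, with a stated time of 24 h; a higher number here means a weaker inhibitor, a lower number a stronger inhibitor.
Compound 2 `CC1(C)[C@H]2CC[C@]1(C)N(Cc1cn(-c3ccccc3)nn1)C(=O)C2` gives 90 nM in this assay.

Compound 2 stands level with compound 1 in this assay: the step of no change at the digits printed from compound 1 to compound 2 (within the scatter), hydrogen in place of fluoro on an aromatic carbon, left the readout unchanged within the scatter. Within the data shown here, that single step is the only comparison on record for this series, and it concerns the same position that is now altered again.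

Compound 3 `CC1(C)[C@H]2CC[C@]1(C)N(Cc1cn(-c3ccc(Cl)cc3)nn1)C(=O)C2` differs from compound 2 by chloro in place of hydrogen on an aromatic carbon. The change sits where the fluoro of compound 1 once sat, and the step of no change at the digits printed from compound 1 to compound 2 (within the scatter) showed that removing a halogen there cost nothing measurable. Among the measured compounds shown here, with only that comparison to draw on, a swap to a different halogen at the same place is expected to behave alike, so no shift beyond the scatter is anticipated in this assay for compound 3; the expected step is no change at the digits printed from compound 2 to compound 3 (within the scatter).

Compound 3 is therefore estimated at 90 nM in this assay, with an expected range from 40 nM to 200 nM.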

Compound 3, half-maximal inhibitory concentration: 90 nM
Beside the measured number, compound 3's estimate shows no gap at the digits printed, and the stated range covers the measured number.
By their numbers in this assay, from the lowest: compounds 1, 2 and 3 (each within the scatter of the next).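

In this assay, placing chloro on the aromatic carbon, phenyl to 4-chlorophenyl, gives no change at the digits printed from compound 2 to compound 3 (within the scatter). The earlier comparison concerned fluoro alone, so this extends the same flat reading to a second halogen at this place on the six-membered aromatic ring. The direct exchange of one halogen for the other gives no change at the digits printed from compound 1 to compound 3 (within the scatter), which places hydrogen, fluoro and chloro level with one another here, and no supporting data are available to explain this flat result.

Among the compounds shown, this position carries only hydrogen and these two halogens, so it remains open whether a group of another kind, such as methoxy, an amine or a carboxylic acid, would shift the value beyond the scatter. Going by these compounds, it is also open whether changes elsewhere on the shared core would leave the reading just as flat, since all three compounds differ only at this one place.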